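A few compounds are considered here, and "the series" means these few. Any claim that something is new, unique, unknown or untested is made for them only; others in the source may bear on it.

Measured compounds:
- compound 1, `CCCCCCCCn1cc(/C=C/C(=O)c2ccc(NC(=O)CN3CCN(c4ccc([N+](=O)[O-])cc4)CC3)cc2)nn1`, 30200 nM
- compound 2, `CCCCCCCCCCn1cc(/C=C/C(=O)c2ccc(NC(=O)CN3CCN(C(=O)OC(C)(C)C)CC3)cc2)nn1`, 30200 nM

In a functional assay on HeLa cells (Homo sapiens) for inhibition, read by MTT assay (a higher number here means a weaker inhibitor, a lower number a stronger inhibitor), compound 1 gives 30200 nM. In this assay compound 2 gives 30200 nM. Among the compounds with values here, compound 2 stands level with compound 1 at the digits printed; the two compounds differ in two places at once, so their equal values say only that the pair together makes no difference beyond the scatter.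

Compound 3, `CCCCCCCCCCn1cc(/C=C/C(=O)c2ccc(NC(=O)CN3CCN(c4ccc([N+](=O)[O-])cc4)CC3)cc2)nn1`, has not yet been measured in this assay. It differs from compound 2 in one place: 4-nitrophenyl in place of tert-butoxycarbonyl on an amine nitrogen in a ring. The group that enters in compound 3 is the same one that sits on compound 1, and compound 1 gave 30200 nM. With compound 1 and compound 2 both at the same value, no direction beyond the scatter is expected. The step of a 1.0-fold lower number from compound 2 to compound 3 (0.00 log units; within the scatter) is estimated to lie within the scatter. For compound 3 the expected value in this assay is 30000 nM, with a range from 12000 nM to 70000 nM.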

Compound 3, half-maximal inhibitory concentration: 65900 nM
The estimate for compound 3 lay 2.2-fold (0.34 log units) below the measured number, within the range that was stated.
By their numbers in this assay, from the lowest: compounds 1 and 2 (each within the scatter of the next); then compound 3.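

In this assay, 4-nitrophenyl in place of tert-butoxycarbonyl on the amine nitrogen in the ring gives a 2.2-fold higher number from compound 2 to compound 3 (0.34 log units; beyond the scatter), so with the chain held constant this position does respond to the change, which the pair of compound 1 and compound 2, differing in two places at once, could not show. With 4-nitrophenyl held constant, ethyl in place of hydrogen on a saturated chain carbon, eight bonds along the chain from an aromatic nitrogen, gives a 2.2-fold higher number from compound 1 to compound 3 (0.34 log units; beyond the scatter), so the level values of compound 1 and compound 2 turn out to join two single changes that each move the number beyond the scatter, in opposite directions along the path through compound 3. Nothing offered here bears on why either step arises.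

Still open is whether the step at the ring nitrogen would look the same on the shorter chain of compound 1, since the pairing of that chain with tert-butoxycarbonyl is not among the compounds shown. Also open, as far as these compounds go, is how other groups there, such as acetyl or 4-aminophenyl, or a butyl or dodecyl chain on the aromatic nitrogen, would read.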